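The source may report more compounds than this note shows. Statements on the series, on what has been measured and on what is new or still open speak of the compounds shown alone.

Compound 1 `CC(=O)Nc1cccc(-c2ccc(C(=O)N(Cc3cccc(OCCCCCC(=O)O)c3)C(C)C)cc2)c1`: in an ADME assay on BJ cells (Homo sapiens) for cytotoxicity, read by CellTiter-Glo and resazurin assay, with a stated time of 72 h (a lower number here means that less compound is needed, a higher number that more compound is needed for the effect), compound 1 gives > 26000 nM, which is a limit of the assay and not a number.
Compound 2 `CC(C)N(Cc1cccc(OCCCCCC(=O)O)c1)C(=O)c1ccc(-c2ccncc2)cc1`: compound 2 gives > 26000 nM, again a limit of the assay.
Compound 3 `CC(C)Oc1cccc(-c2ccc(C(=O)N(Cc3cccc(OCCCCCC(=O)O)c3)C(C)C)cc2)c1`: compound 3 gives > 26000 nM, also only a limit.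

Compound 3 thus stands where the other two stand, at the limit of > 26000 nM in this assay, at which 3 of the 3 values shown sit. No ordering among the three can be read from such limits.

The next compound, compound 4 `COc1cc(OC)cc(-c2ccc(C(=O)N(Cc3cccc(OCCCCCC(=O)O)c3)C(C)C)cc2)c1`, is obtained from compound 3 by a single change: 3,5-dimethoxyphenyl in place of 3-isopropoxyphenyl on an aromatic carbon. The aryl group para to the large amide-bearing part is exchanged, and the count of hydrogen-bond acceptors on that ring rises by one.

The measured steps that bear on this position are a step that the two limits leave unreadable from compound 1 to compound 2, a step that the two limits leave unreadable from compound 1 to compound 3 and a step that the two limits leave unreadable from compound 2 to compound 3. Going by the values given here, each of them joins two limits, so none gives a readable size or direction, and they show only that swapping the aryl group at this carbon has not yet produced a value inside the measured window.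

On that basis compound 4 is expected to behave like its neighbours, with a step from compound 3 of a step that the limit leaves unreadable from compound 3 to compound 4 that is not expected to exceed the scatter. Compound 4 is therefore estimated at 40000 nM, with a range from 15000 nM to 120000 nM, most likely reported again as a limit.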

Compound 4, half-maximal effective concentration: > 26000 nM
Compound 4 ended at the assay's limit; the forecaster's own chance of this, stated with the estimate: 85%; the middle value lies beyond the limit too.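

In this assay compound 4 gives > 26000 nM, again a limit and not a number. Its steps to compound 1, compound 2 and compound 3 therefore cannot be read in size or direction: the limit of > 26000 nM in this assay, at which 4 of the 4 values shown sit. The compounds shown leave open whether any group on this aromatic carbon gives a value inside the measured window of this assay, and how these four compounds rank.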